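The source may report more compounds than this note shows. Statements on the series, on what has been measured and on what is new or still open speak of the compounds shown alone.

For the measured compounds named here, in a functional assay on MCF7 cells (Homo sapiens) for antiproliferative activity, read by MTT assay, with a stated time of 48 h (a higher number here means a weaker inhibitor, a lower number a stronger inhibitor), two compounds sharing one core have numbers so far. Going by the values given here, compound 1 `Fc1ccc(NCc2cn(-c3ccccc3)nc2-c2ccc(Cl)cc2)cc1` gives 1880 nM, and compound 2 `Clc1ccc(-c2nn(-c3ccccc3)cc2CNc2ccc(Br)cc2)cc1` gives 2620 nM, which places compound 2 within the usual scatter of the only other measured compound. Compound 3 `Clc1ccc(NCc2cn(-c3ccccc3)nc2-c2ccc(Cl)cc2)cc1` has not yet been measured. It differs from compound 2 by chloro in place of bromo on an aromatic carbon, para to a large group. Among the compounds with values here, one measured step bears on this change, bromo in place of fluoro on an aromatic carbon, which gave a 1.4-fold higher number from compound 1 to compound 2 (0.14 log units; within the scatter). That step stays within the scatter, so no step beyond the scatter is expected in this assay, and no firm direction can be claimed. The expected step is a 1.2-fold lower number from compound 2 to compound 3 (0.08 log units; within the scatter). The estimate for compound 3 is 2200 nM, with an expected range from 1200 nM to 4000 nM.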

Compound 3, half-maximal inhibitory concentration: 2280 nM
Beside the measured number, compound 3's estimate is 1.0-fold (0.02 log units) below it, and the stated range covers the measured number.
By their numbers in this assay, from the lowest: compounds 1, 3 and 2 (each within the scatter of the next).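

In this assay, chloro in place of bromo gives a 1.1-fold lower number from compound 2 to compound 3 (0.06 log units; within the scatter) and chloro in place of fluoro gives a 1.2-fold higher number from compound 1 to compound 3 (0.08 log units; within the scatter), both within the scatter. Fluoro, chloro and bromo on this aromatic carbon, para to a large group, therefore cannot be told apart in this read-out, and the three compounds show no dependence on which of these halogens sits there. No measurement is at hand that would explain this result.

Going by these compounds, whether a group of another kind at this place, such as methoxy, an amine or a carboxylic acid, would move the number beyond the scatter stays open, as does the effect of plain hydrogen there. The compounds shown also carry the same phenyl and 4-chlorophenyl groups on the shared core, so they say nothing about changes at those places.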